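The source may hold more compounds than are shown below. What is called first, only, known or untested is meant among the compounds shown, and "the series" means these compounds.

Compound 3 `CCOC(=O)CCCCCOc1cccc(CN(C(=O)c2ccc(-c3cccc(N(C)C)c3)cc2)C(C)C)c1` was examined in an ADME assay on HEK293 cells (Homo sapiens) for cytotoxicity, read by CellTiter-Glo and resazurin assay, with a stated time of 72 h; on this read-out lower numbers stand for an effect already at smaller amounts and higher numbers for an effect only at larger amounts of compound. In this assay compound 3 gives only a limit, > 26000 nM. Compound 1 `CC(C)N(Cc1cccc(OCCCCCC(=O)O)c1)C(=O)c1ccc(-c2cccc(N(C)C)c2)cc1` also reaches only a limit in this assay, > 26000 nM. Compound 2 `CC(C)N(Cc1cccc(OCCCCCC(=O)O)c1)C(=O)c1ccc(-c2ccc3c(c2)OCCO3)cc1` likewise stops at a limit in this assay, > 21900 nM. Two of the three values sit at the limit of > 26000 nM in this assay, at which 2 of the 3 values shown sit, and the third at the limit of > 21900 nM in this assay, at which 1 of the 3 values shown sits, so every number shown is a limit rather than a measured point. As a result the step that the two limits leave unreadable from compound 1 to compound 2 cannot be read, and the same holds for the step that the two limits leave unreadable from compound 1 to compound 3.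

Compound 4 `CCOC(=O)CCCCCOc1cccc(CN(C(=O)c2ccc(-c3ccc4cc[nH]c4c3)cc2)C(C)C)c1` differs from compound 3 by 1H-indol-6-yl in place of 3-(dimethylamino)phenyl on an aromatic carbon. Among the measured compounds shown here, the only other change of the aryl group among the measured compounds is the unreadable step that the two limits leave unreadable from compound 1 to compound 2, and the change of the ester end, a step that the two limits leave unreadable from compound 1 to compound 3, is equally unreadable; no measured step gives a size or a direction for this change. Compound 4 is therefore expected to remain at a limit as well, around 26000 nM within 13000 nM to 52000 nM, which means an estimated step of a number no higher from compound 3 to compound 4 (the limit leaves the size open).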

Compound 4, half-maximal effective concentration: > 26000 nM
Compound 4 ended at the assay's limit; the forecaster's own chance of this, stated with the estimate: 80%; the middle value lies on the limit itself.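

In this assay compound 4, like compound 3, stops at a limit, so the change to 1H-indol-6-yl gives no readable step: the limit of > 26000 nM in this assay, at which 3 of the 4 values shown sit. The compounds shown leave open whether either the aryl group or the ester end shifts cytotoxicity at all.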